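A Tetrazole in Place of Fluorine on a Shared Core

A few compounds are considered here, and "the series" means these few. Any claim that something is new, unique, unknown or untested is made for them only; others in the source may bear on it.

Compound 3 `Fc1ccc(Nc2cc3[nH]c(-c4cccc(C(F)(F)F)c4)nc3cn2)nc1` was measured in a physicochemical assay for solubility, using the shake flask method, in phosphate buffer, measured as kinetic solubility, with a stated time of 20 h, at pH 6.5; a higher number here means a more soluble compound, a lower number a less soluble compound. Compound 3 gives only a limit there, < 5000 nM. Compound 1 `COc1cccnc1Nc1cc2[nH]c(-c3cccc(C(F)(F)F)c3)nc2cn1` likewise gives only a limit, < 5000 nM. Compound 2 `COc1ccnc(Nc2cc3[nH]c(-c4cccc(C(F)(F)F)c4)nc3cn2)c1` also gives only a limit, < 5000 nM. All three values sit at the same point, (the limit of < 5000 nM in this assay, at which 3 of the 3 values shown sit), so the steps a step that the two limits leave unreadable from compound 1 to compound 2, a step that the two limits leave unreadable from compound 1 to compound 3 and a step that the two limits leave unreadable from compound 2 to compound 3 cannot be read in size or direction. Compound 4 `FC(F)(F)c1cccc(-c2nc3cnc(Nc4ccc(-c5nnn[nH]5)cn4)cc3[nH]2)c1` differs from compound 3 by 1H-tetrazol-5-yl in place of fluoro on an aromatic carbon. Among the measured compounds shown here, none of the measured steps bears on this change, since each pairs two limits. The solubility of compound 4 is nevertheless expected to rise by an at least 3.0-fold higher number from compound 3 to compound 4 (0.47 log units; beyond the scatter). The estimate for compound 4 is 15000 nM, within a range from 3000 nM to 80000 nM.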

Compound 4, solubility: < 5000 nM
Compound 4 ended at the assay's limit; the forecaster's own chance of this, stated with the estimate: 30%; middle value at least 3.0-fold (0.47 log units) away from the limit.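

In this assay compound 3 and compound 4 both give only a limit, and no new step can be read between them. The compounds shown leave open how far any of the four lies under that limit, and so what 1H-tetrazol-5-yl in place of fluoro does to solubility.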